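Triazole nitrogen substituent variation in a flavanone series

A few compounds are considered here, and "the series" means these few. Any claim that something is new, unique, unknown or untested is made for them only; others in the source may bear on it.

Of the compounds shown here, three of one core have been measured. Compound 1 `COc1ccc([C@@H]2CC(=O)c3c(O)cc(OCc4cn(Cc5cccc(C(F)(F)F)c5)nn4)cc3O2)cc1O` gives 19900 nM in a functional assay on RAW264.7 cells (Mus musculus) for inhibition, read by Griess assay, with stated times of 2 h and 24 h; on this read-out lower numbers stand for stronger inhibition and higher numbers for weaker inhibition. Compound 2 `CCn1cc(COc2cc(O)c3c(c2)O[C@H](c2ccc(OC)c(O)c2)CC3=O)nn1` gives 15000 nM, and compound 3 `COc1ccc([C@@H]2CC(=O)c3c(O)cc(OCc4cn(Cc5ccccc5)nn4)cc3O2)cc1O` gives 11000 nM. Compound 1 carries the highest number of the three, yet the steps of a 1.3-fold lower number from compound 1 to compound 2 (0.12 log units; within the scatter) and a 1.8-fold lower number from compound 1 to compound 3 (0.26 log units; within the scatter) both stay within the scatter, as does a 1.4-fold lower number from compound 2 to compound 3 (0.13 log units; within the scatter). Compound 4 `COc1ccc([C@@H]2CC(=O)c3c(O)cc(OCc4cn(CCCO)nn4)cc3O2)cc1O` differs from compound 1 by 2-hydroxyethyl in place of 3-(trifluoromethyl)phenyl on a saturated chain carbon bound to an aromatic nitrogen; cut one bond further out, this reads 3-(trifluoromethyl)benzyl to 3-hydroxypropyl. For the measured compounds named here, the nearest precedent is the step of a 1.3-fold lower number from compound 1 to compound 2 (0.12 log units; within the scatter), where a methyl replaced the same 3-(trifluoromethyl)phenyl on that saturated chain carbon without a change beyond the scatter. For compound 4 a step of a 1.3-fold lower number from compound 1 to compound 4 (0.12 log units; within the scatter) is therefore expected, with an estimate of 15000 nM and a range of 6000 nM to 40000 nM.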

Compound 4, half-maximal inhibitory concentration: 16700 nM
Compound 4: middle estimate off by 1.1-fold (0.05 log units), on the low side; low and high end bracket the measured number.
By their numbers in this assay, from the lowest: compounds 3, 2, 4 and 1 (each within the scatter of the next).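

In this assay, 3-hydroxypropyl on the aromatic nitrogen stays within the scatter of all three earlier substituents, as shown by a 1.2-fold lower number from compound 1 to compound 4 (0.08 log units; within the scatter) and a 1.5-fold higher number from compound 3 to compound 4 (0.18 log units; within the scatter) and a 1.1-fold higher number from compound 2 to compound 4 (0.05 log units; within the scatter). Across these four compounds, a terminal hydroxyl, with its hydrogen-bond donor and acceptor, therefore gives no step beyond the scatter at this position. No supporting measurement is available to explain this flat result.

As far as these compounds go, whether a primary amine or a carboxylic acid at the end of this chain would move the number beyond the scatter remains open. So does the effect of a longer chain carrying the terminal hydroxyl.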